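Furan to Fluorophenyl: Expected Shift in Cell Inhibition

A few compounds are considered here, and "the series" means these few. Any claim that something is new, unique, unknown or untested is made for them only; others in the source may bear on it.

Compound 1 `Cc1cc(-c2ncnc3c2ncn3C2O[C@H](CO)[C@@H](O)[C@H]2O)on1`: "not active" (no number reported)
Compound 2 `OC[C@H]1OC(n2cnc3c(-c4ccoc4)ncnc32)[C@H](O)[C@@H]1O`: 1650 nM

Among the compounds with values here, in a functional assay on CCRF-CEM cells (Homo sapiens) for inhibition (on this read-out higher numbers stand for weaker inhibition and lower numbers for stronger inhibition), compound 2 gives 1650 nM, the only number reported in this set; compound 1 is reported as "not active" (no number reported) without a number. Compound 3 `OC[C@H]1OC(n2cnc3c(-c4ccc(F)cc4)ncnc32)[C@H](O)[C@@H]1O` differs from compound 2 by 4-fluorophenyl in place of furan-3-yl on an aromatic carbon. Within the data shown here, no measured pair shows what such a swap does, so the direction is open. A small gain in potency is expected, somewhat beyond the usual scatter, as the step of a 1.8-fold lower number from compound 2 to compound 3 (0.26 log units; within the scatter). Compound 3 is therefore estimated at 900 nM, with a plausible range from 200 nM to 5000 nM.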

Compound 3, half-maximal inhibitory concentration: 700 nM
Compound 3: the middle estimate sits 1.3-fold (0.11 log units) above what was measured, and the stated range covers the measured number.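

In this assay, 4-fluorophenyl in place of furan-3-yl gives a 2.4-fold lower number from compound 2 to compound 3 (0.37 log units; beyond the scatter), a modest gain in inhibition. This position therefore tolerates a six-membered aromatic ring of carbon only, even without the hydrogen-bond acceptor of the furan, and inhibition does not suffer. No measurement here explains the gain. The compounds shown leave open whether the fluorine or the six-membered ring accounts for this step, as plain phenyl is not among them. As far as these compounds go, how an amine or a carboxylic acid at this position would fare also remains open.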